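A few compounds are considered here, and "the series" means these few. Any claim that something is new, unique, unknown or untested is made for them only; others in the source may bear on it.

Measured so far:
- compound 1, `CC(Sc1nc2c(cnn2C)c(=O)n1-c1ccccc1)c1ccccn1`, gives 97% in an assay on PEO1 cells for inhibition of Retinaldehyde dehydrogenase 3 (Homo sapiens), read by flow cytometry, with a stated time of 30 min, tested at 1 uM; on this read-out lower numbers stand for less inhibition and higher numbers for more inhibition at the one concentration tested (going by the name of the read-out)
- compound 2, `CC(Sc1nc2c(cnn2C)c(=O)n1-c1ccccc1)c1ccccc1`, gives 47% in this assay
- compound 3, `C[C@H](Sc1nc2c(cnn2C)c(=O)n1-c1ccccc1)c1ccccc1`, gives 2% in this assay

Compound 3 stands lowest of the three numbers; its nearest neighbour is compound 2, and compound 1 is furthest away. The step of a number 45 percentage points lower from compound 2 to compound 3 (beyond the scatter) separates compound 3 from compound 2, and the step of a number 95 percentage points lower from compound 1 to compound 3 (beyond the scatter) separates it from compound 1.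

Compound 4, `CC(Sc1nc2c(cnn2C)c(=O)n1-c1ccccc1)c1cccnc1`, has not yet been measured in this assay. It differs from compound 3 in one place: 1-(pyridin-3-yl)ethyl in place of 1-phenylethyl on a sulfur. Two earlier steps speak to this change. The step of a number 50 percentage points lower from compound 1 to compound 2 (beyond the scatter) shows that swapping a pyridine ring for a plain phenyl ring on the same chain carbon cost a large part of the signal, so restoring a ring nitrogen may win some back. The step of a number 45 percentage points lower from compound 2 to compound 3 (beyond the scatter) shows that drawing the stereocentre as a single configuration also lowered the number, a point supported by the fact that one of compounds 2 and 3 is drawn with a defined configuration and the other without, at the place where they differ, and compound 4 is again drawn without a configuration. Both considerations point upward, though the nitrogen now sits in a different ring position than in compound 1, so the full recovery seen there cannot be assumed. A rise beyond the scatter is expected, as a number 43 percentage points higher from compound 3 to compound 4 (beyond the scatter). Compound 4 is therefore estimated at 45%, within a range from 10% to 85%.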

Compound 4, a percentage reported as inhibition, at one concentration (the size of the read-out at that concentration, not a potency): 95%
Estimate against measurement, compound 4: 50 percentage points below; measured number above the stated range.
By their numbers in this assay, from the lowest: compound 3; then compound 2; then compounds 4 and 1 (each within the scatter of the next).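

In this assay, the rise is not tied to pyridin-2-yl alone: with both compounds drawn without a configuration, pyridin-3-yl in place of phenyl gives a number 48 percentage points higher from compound 2 to compound 4 (beyond the scatter). The two pyridine rings cannot be told apart here, with a number 2 percentage points lower from compound 1 to compound 4 (within the scatter), so among these compounds the presence of a ring nitrogen matters more than which of these two pyridine rings carries it. The largest step, a number 93 percentage points higher from compound 3 to compound 4 (beyond the scatter), is harder to read as a ring effect alone, as it also includes a change in how the stereocentre is drawn, a difference already present in an earlier pair: the fact that one of compounds 2 and 3 is drawn with a defined configuration and the other without, at the place where they differ.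

Going by these compounds alone, whether pyridin-4-yl or a pyrimidine ring on the same chain carbon would hold the number as high remains open, as does what the single configurations of compound 1 and compound 4 would give. With only one tested concentration, the read-out also cannot show whether compound 1 and compound 4 differ in potency.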